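The source may report more compounds than this note shows. Statements on the series, on what has been measured and on what is new or still open speak of the compounds shown alone.

Compound 1 `C#CCSc1nnc(CC)n1N1C(=O)c2ccccc2C1=O` gives > 200000 nM in a functional assay on MKN-45 cells (Homo sapiens) for cytotoxicity, read by MTT assay, with a stated time of 48 h (a lower number here means a stronger inhibitor, a higher number a weaker inhibitor), a limit of the assay.
Compound 2 `CCc1nnc(SCC(=O)c2ccccc2)n1N1C(=O)c2ccccc2C1=O` gives > 200000 nM in this assay, likewise a limit.
Compound 3 `CCc1nnc(SCC(=O)c2ccc(C)cc2)n1N1C(=O)c2ccccc2C1=O` gives > 200000 nM in this assay, again a limit.

Compound 3 therefore stands only at a limit in this assay, and the same is true of the two other measured compounds, as the limit of > 200000 nM in this assay, at which 3 of the 3 values shown sit, shows. Compound 4 `CCCc1nnc(SCC(=O)c2ccc(C)cc2)n1N1C(=O)c2ccccc2C1=O` differs from compound 3 by methyl in place of hydrogen on a saturated chain carbon, two bonds along the chain from an aromatic carbon. The measured steps that bear on it are a step that the two limits leave unreadable from compound 1 to compound 2, a step that the two limits leave unreadable from compound 1 to compound 3 and a step that the two limits leave unreadable from compound 2 to compound 3, none of which can be read as a size, since both ends of each sit at the limit. The closest analogue in kind, a small alkyl addition, is the step from compound 2 to compound 3, which is itself unreadable. With no readable step in this assay and every measured value at the limit, no step beyond the scatter is expected. The step that the limit leaves unreadable from compound 3 to compound 4 is accordingly estimated as none beyond the scatter. Compound 4 is expected at 300000 nM, within 100000 nM to 1000000 nM, and most probably will again be reported only as a limit.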

Compound 4, half-maximal inhibitory concentration: > 200000 nM
Compound 4: no number, only a limit; the forecaster's own chance of this, stated with the estimate: 85%; the middle value is on the limit's open side.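

Compound 4 gives > 200000 nM in this assay, a limit of the assay. With compound 3 also at a limit, no new step can be read for this pair. The compounds shown leave open which change, if any, would bring a measurable value, as the series rests at one limit: the limit of > 200000 nM in this assay, at which 4 of the 4 values shown sit.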